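Swapping the Thiophene Arm for a Hydroxyethyl Arm

The source may report more compounds than this note shows. Statements on the series, on what has been measured and on what is new or still open speak of the compounds shown alone.

Measured so far:
compound 1 `O=[N+]([O-])c1c(CS(=O)(=O)c2ccccc2)nc2c(C#Cc3ccccc3)cc(Cl)cn12` in an ADME assay on HepG2 cells (Homo sapiens) for cytotoxicity, read by MTT assay, with a stated time of 72 h (a higher number here means that more compound is tolerated, a lower number that less compound is tolerated), gives > 3900 nM, a limit of the assay.
compound 2 `COc1cccc(C#Cc2cc(Cl)cn3c([N+](=O)[O-])c(CS(=O)(=O)c4ccccc4)nc23)c1` gives > 3900 nM, again a limit.
compound 3 `O=[N+]([O-])c1c(CS(=O)(=O)c2ccccc2)nc2c(C#Cc3cccs3)cc(Cl)cn12` gives > 3900 nM, also a limit.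

Compound 3 therefore stands where every measured compound stands: at the limit of this assay, with no number of its own. Because of the limit of > 3900 nM in this assay, at which 3 of the 3 values shown sit, none of the three comparisons among these compounds can be read as a step of any size. The change from compound 1 to compound 2 is a step that the two limits leave unreadable from compound 1 to compound 2, the change from compound 1 to compound 3 is a step that the two limits leave unreadable from compound 1 to compound 3, and the change from compound 2 to compound 3 is a step that the two limits leave unreadable from compound 2 to compound 3.

Compound 4 `CC(O)C#Cc1cc(Cl)cn2c([N+](=O)[O-])c(CS(=O)(=O)c3ccccc3)nc12` differs from compound 3 by 1-hydroxyethyl in place of thiophen-2-yl on a triple-bonded carbon. The two measured steps that touch the same triple-bonded carbon, a step that the two limits leave unreadable from compound 1 to compound 3 and a step that the two limits leave unreadable from compound 2 to compound 3, are the ones that bear on this change, and both are unreadable due to the limit of > 3900 nM in this assay, at which 3 of the 3 values shown sit. Going by the values given here, no measured compound carries a 1-hydroxyethyl group. The expectation is that compound 4 shows no step beyond the scatter, a step that the limit leaves unreadable from compound 3 to compound 4, and most likely sits at the limit as well. Compound 4 is estimated at 6000 nM, in the range 3000 nM to 25000 nM.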

Compound 4, half-maximal cytotoxic concentration: 44200 nM
Estimate against measurement, compound 4: 7.4-fold (0.87 log units) below, outside the stated range (above it).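

Going by these compounds alone, compound 4 now has a number of its own in this assay, yet no step from compound 1, compound 2 or compound 3 to compound 4 can be read, due to this: the limit of > 3900 nM in this assay, at which 3 of the 4 values shown sit.

Still open, from the compounds shown here alone, is how far the true values of compound 1, compound 2 and compound 3 lie from that of compound 4.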